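Adding a Methoxy Group Where Three Compounds Show Only Limits

The compounds below may be only part of what the source reports. "The series", "measured", "known", "first", "only" and "open" are said of these compounds alone.

Compound 2 `COc1cccc(/C=C/C(=O)c2ccc(OC)c([N+](=O)[O-])c2)c1` is the starting point. In a functional assay on B16 cells (Mus musculus) for cytotoxicity, read by MTT assay, with a stated time of 3 days (on this read-out lower numbers stand for stronger inhibition and higher numbers for weaker inhibition), compound 2 gives > 100000 nM, which is a limit of the assay rather than a measured number. Its two nearest relatives stand the same way. Compound 1 `COc1ccc(C(=O)/C=C/c2ccccc2)cc1[N+](=O)[O-]` gives > 100000 nM in this assay, also a limit. Compound 3 `COc1ccc(/C=C/C(=O)c2ccc(OC)c([N+](=O)[O-])c2)cc1OC` gives > 100000 nM in this assay, again a limit. The step from compound 1 to compound 2 is a step that the two limits leave unreadable from compound 1 to compound 2, and the step from compound 2 to compound 3 is a step that the two limits leave unreadable from compound 2 to compound 3. Each of these steps is a methoxy in place of hydrogen on an aromatic carbon, and because the limit of > 100000 nM in this assay, at which 3 of the 3 values shown sit, neither of them can be given a size.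

Compound 4 `COc1ccc(OC)c(/C=C/C(=O)c2ccc(OC)c([N+](=O)[O-])c2)c1` differs from compound 2 by methoxy in place of hydrogen on an aromatic carbon. The two measured steps of the same kind bear on this change, but their sizes are not readable; they show only that such additions have not brought any compound out of the limit into a measurable number. The step expected in this assay is a step that the limit leaves unreadable from compound 2 to compound 4, with the most likely outcome being that compound 4 again sits at the limit. Compound 4 is expected to give 150000 nM in this assay, with a range from 30000 nM to 1000000 nM.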

Compound 4, half-maximal inhibitory concentration: 13000 nM
Compound 4: the middle estimate sits 12-fold (1.06 log units) above what was measured, and the stated range ends above it.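

Placing a methoxy group in this position, on an aromatic carbon ortho to a large group and para to a methoxy group, gives an at least 7.6-fold lower number from compound 2 to compound 4 (0.88 log units; beyond the scatter) in this assay. This shows that adding a single methoxy group to this ring can bring a compound of this series off the limit and give it a measured number, which neither earlier addition had done. The two earlier methoxy steps still cannot be read, because both ends of each step sit at the same limit: the limit of > 100000 nM in this assay, at which 3 of the 4 values shown sit.

The compounds shown do not say whether this gain depends on the methoxy group itself, or whether a smaller or different group in the same place, such as a hydroxyl, a fluorine or an amine, would also lift compound 2 off the limit. They also leave open whether the methoxy group para to the new one is needed, since a single compound carries this arrangement and one step cannot establish a pattern.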